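A group swap on a compound without a number

The source may report more compounds than this note shows. Statements on the series, on what has been measured and on what is new or still open speak of the compounds shown alone.

Measured in a physicochemical assay for permeability, using PAMPA; on this read-out lower numbers stand for lower permeability and higher numbers for higher permeability:
- compound 1 `Cc1cc(C)c(-c2nc(CN3CCC(C(=O)NCCCN4C[C@H](C)C[C@H](C)C4)CC3)c(C)o2)c(C)c1`: "not determined" (no result reported)
- compound 2 `Cc1ccccc1-c1nc(CN2CCC(C(=O)NCCCN3CC(C)(C)CC(C)(C)C3)CC2)c(C)o1`: > 1390 10^-6 cm/s (a limit of the assay, not a number)
- compound 3 `Cc1ccccc1-c1nc(CN2CCC(C(=O)NCCCN3[C@H](C)CCC[C@@H]3C)CC2)c(C)o1`: 55.4 10^-6 cm/s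

Compound 1 has no place on this scale, since its entry reads "not determined" (no result reported). Any comparison with it therefore lacks a starting point.

Compound 4 `Cc1oc(-c2c(Br)cccc2Br)nc1CN1CCC(C(=O)NCCCN2C[C@H](C)C[C@H](C)C2)CC1` differs from compound 1 in a single place: 2,6-dibromophenyl in place of 2,4,6-trimethylphenyl on an aromatic carbon. In words, this is 2,6-dibromophenyl in place of 2,4,6-trimethylphenyl on an aromatic carbon.

The only measured step among these compounds is an at least 25-fold lower number from compound 2 to compound 3 (1.39 log units; beyond the scatter). It is large, but it concerns a group on a saturated chain carbon, not the group that changes here, so it says nothing about this swap. What it does show is how far apart close relatives can lie in this assay.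

The other reading to keep in mind is the limit of > 1390 10^-6 cm/s in this assay, at which 1 of the 3 values shown sits, which belongs to compound 2 and is a limit.

No size or direction can therefore be expected for the change from compound 1, and the estimate has to stand alone. It leans on compound 3 at 55.4 10^-6 cm/s, and the size of an at least 25-fold lower number from compound 2 to compound 3 (1.39 log units; beyond the scatter) calls for a wide range.

For compound 4 the estimated value is 200 10^-6 cm/s, with an expected range from 40 10^-6 cm/s to 1000 10^-6 cm/s.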

Compound 4, apparent permeability: < 1 10^-6 cm/s
Compound 4 ended at the assay's limit (the forecaster's own chance of this, stated with the estimate: 15%); middle value at least 200-fold (2.30 log units) away from the limit.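

Going by these compounds alone, compound 1 carries no number on this scale, so no step to compound 4 can be read. In this assay compound 4 gives < 1 10^-6 cm/s, which is a limit of the assay and not a number. The compounds shown leave open how much, and in which direction, 2,6-dibromophenyl in place of 2,4,6-trimethylphenyl shifts the read-out on its own.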